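Adding amino to the ethynyl methoxy compound

This account rests on a few compounds, and the source may have more. Where it says the series, first, only, none or still open, it means among the compounds named here.

Among the measured compounds shown here, in a functional assay on A549 cells (Homo sapiens), read by MTT assay, with a stated time of 72 h (a higher number here means a weaker inhibitor, a lower number a stronger inhibitor), compound 2 `C#Cc1cn([C@@H]2O[C@H](CO)[C@@H](O)[C@H]2O)c2ncnc(OC)c12` gives 8160 nM, the lowest number of the three measured so far. Compound 1 `COc1ncnc2c1c(-c1cc3ccccc3o1)cn2[C@@H]1O[C@H](CO)[C@@H](O)[C@H]1O` gives 17700 nM, and compound 3 `C#Cc1cn([C@@H]2O[C@H](CO)[C@@H](O)[C@H]2O)c2ncnc(C)c12` gives 19200 nM.

The next compound is compound 4 `C#Cc1cn([C@@H]2O[C@H](CO)[C@@H](O)[C@H]2O)c2nc(N)nc(OC)c12`, which differs from compound 2 as follows: amino in place of hydrogen on an aromatic carbon. The new amino group sits on the carbon between two ring nitrogen atoms.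

Two measured steps exist: a 2.2-fold lower number from compound 1 to compound 2 (0.34 log units; beyond the scatter) and a 2.4-fold higher number from compound 2 to compound 3 (0.37 log units; beyond the scatter). Both are modest, and neither involves this carbon, so the data give no direct reading for amino in place of hydrogen. For the measured compounds named here, they show only that both single changes away from compound 2 ended at a higher number. On that limited basis, a modest rise of similar size is expected in this assay, though with wide uncertainty. The expected change is a 2.0-fold higher number from compound 2 to compound 4 (0.29 log units; within the scatter). For compound 4 the estimated value is 16000 nM. The expected range for compound 4 runs from 5000 nM to 50000 nM.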

Compound 4, half-maximal inhibitory concentration: > 100000 nM
Compound 4 was reported as a limit; the forecaster's own chance of this, stated with the estimate: 20%; at least 6.2-fold (0.79 log units) between middle value and limit.
By their numbers in this assay, from the lowest: compound 2; then compounds 1 and 3 (each within the scatter of the next). At a limit, above all of these: compound 4.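

In this assay compound 4 gives > 100000 nM, which is a limit of the assay and not a number. Amino in place of hydrogen gives an at least 12-fold higher number from compound 2 to compound 4 (1.08 log units; beyond the scatter), against the modest 2.2-fold lower number from compound 1 to compound 2 (0.34 log units; beyond the scatter) and a 2.4-fold higher number from compound 2 to compound 3 (0.37 log units; beyond the scatter) from changes made elsewhere on the core. The carbon between two ring nitrogen atoms, which carries hydrogen in compound 1, compound 2 and compound 3, is therefore the most sensitive place tested so far in this small set, though the full size of the step remains unknown: the limit of > 100000 nM in this assay, at which 1 of the 4 values shown sits.

From the compounds shown here alone, whether the rise belongs to amino itself or would follow any group at this carbon stays open; methyl, chlorine or methylamino here would separate the two readings. Also open, going by these compounds, is whether amino has the same effect alongside the methyl of compound 3.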